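Pyrimidin-5-yl enters the thiophene-like core of compound 1

The source may hold more compounds than are shown below. What is called first, only, known or untested is meant among the compounds shown, and "the series" means these compounds.

Compound 1 `Nc1sccc1C(=O)c1ccc(Cl)cc1` gives 50% in an assay on CHO cells for positive allosteric modulation of adenosine receptor A1 (Homo sapiens), read by ERK phosphorylation, tested at 3 uM (a higher number here means a weaker effect of the compound at the concentration tested, a lower number a stronger effect), the highest of the two numbers recorded, while compound 2 `Nc1sc(-c2ccncc2)cc1C(=O)c1ccccc1` gives 23% in this assay, a gap beyond the usual scatter. The step to compound 3 `Nc1sc(-c2cncnc2)cc1C(=O)c1ccc(Cl)cc1` changes one place: pyrimidin-5-yl in place of hydrogen on an aromatic carbon. Because compound 2 with a six-membered aromatic ring at the same place reads 23%, a move to a lower number is expected, though its size is uncertain. Compound 3 is therefore expected to give 30%, between 15% and 50%, a step of a number 20 percentage points lower from compound 1 to compound 3 (beyond the scatter).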

Compound 3, a percentage reported as activity, at one concentration (the size of the read-out at that concentration, not a potency): 7%
Compound 3: the middle estimate sits 23 percentage points above what was measured; measured number outside the range, below it.
By their numbers in this assay, from the lowest: compound 3; then compound 2; then compound 1.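

In this assay, pyrimidin-5-yl in place of hydrogen on the aromatic carbon next to the ring sulfur gives a number 43 percentage points lower from compound 1 to compound 3 (beyond the scatter), so this single change on the core of compound 1 has a large effect on the read-out. Compound 2 differs from compound 3 in more than one place, so it cannot isolate the contribution of this group. Nothing measured here explains the step.

The compounds shown leave open whether phenyl at this place would read like pyrimidin-5-yl. From the compounds shown here alone, how a methyl group or morpholine would compare also remains open.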